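Removing the bromine from a weak sulfone

This account rests on a few compounds, and the source may have more. Where it says the series, first, only, none or still open, it means among the compounds named here.

Of the compounds shown here, three sharing one core have been measured in a functional assay on DU-145 cells (Homo sapiens) for cytotoxicity, read by MTT assay; on this read-out lower numbers stand for stronger inhibition and higher numbers for weaker inhibition. Compound 1 `CC(O)(CS(=O)(=O)c1ccc(Cl)cc1)c1nc(-c2ccc([N+](=O)[O-])c(C(F)(F)F)c2)no1` gives 91000 nM. Compound 2 `CC(O)(CSc1ccc(Br)cc1)c1nc(-c2ccc([N+](=O)[O-])c(C(F)(F)F)c2)no1` gives 1600 nM. Compound 3 `CC(O)(CS(=O)(=O)c1ccc(Br)cc1)c1nc(-c2ccc([N+](=O)[O-])c(C(F)(F)F)c2)no1` returns only the limit of the assay, > 100000 nM, not a number. Compound 3 therefore stands at the weak end of the numbers shown, since the limit of > 100000 nM in this assay, at which 1 of the 3 values shown sits, marks where it sits. The exchange of halogen on the aromatic ring produced an at least 1.0-fold higher number from compound 1 to compound 3 (0.04 log units; that floor lies within the scatter), whereas the change of the sulfur group was large in both directions: a 57-fold lower number from compound 1 to compound 2 (1.75 log units; beyond the scatter) and an at least 62-fold higher number from compound 2 to compound 3 (1.79 log units; beyond the scatter).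

Compound 4 `CC(O)(CS(=O)(=O)c1ccccc1)c1nc(-c2ccc([N+](=O)[O-])c(C(F)(F)F)c2)no1` differs from compound 3 by hydrogen in place of bromo on an aromatic carbon. Of the measured steps, only the halogen exchange bears on this change, and it stayed within the scatter, so a small step at most is expected here, and no step beyond the scatter is expected for the loss of the bromo: a number no higher from compound 3 to compound 4 (the limit leaves the size open). Compound 4 is expected to remain among the weak sulfones, with an estimated 100000 nM in this assay, lying between 40000 nM and 250000 nM, and with a real chance that the assay again reports only a limit for compound 4.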

Compound 4, half-maximal inhibitory concentration: > 100000 nM
Compound 4 was reported as a limit (the forecaster's own chance of this, stated with the estimate: 55%); the middle value sits exactly at the limit.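

With the bromo gone, compound 4 is reported only as a limit, > 100000 nM, in this assay. The phenylsulfonyl compound therefore meets the same ceiling as its 4-bromophenyl partner, compound 3, so the step between these two compounds cannot be read, and removing the bromo brings no measurable activity into view: the limit of > 100000 nM in this assay, at which 2 of the 4 values shown sit. Two steps can still be read, namely an at least 62-fold higher number from compound 2 to compound 4 (1.79 log units; beyond the scatter), which changes both the sulfur group and the halogen, and an at least 1.0-fold higher number from compound 1 to compound 4 (0.04 log units; that floor lies within the scatter), whose floor tells nothing firm about hydrogen in place of chloro.

Hidden behind the limit is whether the sulfones differ at all at higher concentrations, and the compounds shown also leave open whether a sulfanyl compound with hydrogen in place of bromo would keep the activity of compound 2. Also open, going by these compounds, is how an amine or a methoxy group on that same aromatic carbon would behave, and whether a sulfoxide, with one oxygen on the sulfur, would read closer to the sulfanyl or the sulfonyl compounds.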